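Demethylation of a Methoxy Group in a Urea Series

The source may hold more compounds than are shown below. What is called first, only, known or untested is meant among the compounds shown, and "the series" means these compounds.

Compound 1, `COc1cc(-c2nn(-c3cccc(NC(=O)c4cccc(C(F)(F)F)c4)c3)cc2-c2ccncc2)ccc1Cl`, gives 20100 nM in a functional assay on HT-29 cells (Homo sapiens) for inhibition, read by sulforhodamine B assay, with a stated time of 48 h; a lower number here means a stronger inhibitor of growth, a higher number a weaker inhibitor of growth.
Compound 2, `COc1cc(-c2nn(-c3cccc(NC(=O)Nc4ccc(Cl)c(C(F)(F)F)c4)c3)cc2-c2ccncc2)ccc1Cl`, gives 4450 nM in this assay.
Compound 3, `COc1cc(-c2nn(-c3cccc(NC(=O)c4ccccc4)c3)cc2-c2ccncc2)ccc1Cl`, gives only a limit of the assay in this assay, > 100000 nM, and not a number.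

Among the two numbers shown, compound 2 stands lowest; its nearest neighbour is compound 1, separated by the step of a 4.5-fold lower number from compound 1 to compound 2 (0.65 log units; beyond the scatter). The step of an at least 4.9-fold higher number from compound 1 to compound 3 (0.69 log units; beyond the scatter) and the step of an at least 22-fold higher number from compound 2 to compound 3 (1.35 log units; beyond the scatter) both end at the limit (the limit of > 100000 nM in this assay, at which 1 of the 3 values shown sits), so only their minimum size is known.

Compound 4, `O=C(Nc1cccc(-n2cc(-c3ccncc3)c(-c3ccc(Cl)c(O)c3)n2)c1)Nc1ccc(Cl)c(C(F)(F)F)c1`, has not yet been measured. It differs from compound 2 in one place: hydrogen in place of methyl on an oxygen on an aromatic ring. Within the data shown here, none of the measured steps touches the oxygen on the aromatic ring; all three concern the group on the carbonyl carbon or the trifluoromethyl on an aromatic carbon. Among the measured compounds shown here, no measured step therefore bears on this change, and the expectation rests on compound 2 alone. Without evidence in either direction, the estimated step from compound 2 to compound 4 is a 1.1-fold higher number from compound 2 to compound 4 (0.05 log units; within the scatter), within the scatter. Compound 4 is thus expected to give about 5000 nM in this assay, most plausibly between 1500 nM and 16000 nM.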

Compound 4, concentration for total growth inhibition: 5730 nM
Compound 4: the middle estimate sits 1.1-fold (0.06 log units) below what was measured; low and high end bracket the measured number.
By their numbers in this assay, from the lowest: compounds 2 and 4 (each within the scatter of the next); then compound 1. At a limit, above all of these: compound 3.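

Among these compounds, the first change at the oxygen on the aromatic ring, methoxy to hydroxy within 4-chloro-3-methoxyphenyl to 4-chloro-3-hydroxyphenyl, reads in this assay as a 1.3-fold higher number from compound 2 to compound 4 (0.11 log units; within the scatter) and so adds a position that the earlier steps left untouched. Those earlier steps all lay on the group on the carbonyl carbon or on the trifluoromethyl, and each went beyond the scatter, whereas here, in a urea, the methyl on this oxygen gives way to hydrogen with no difference that can be told from that scatter. Nothing in the data shown gives a reason for this outcome.

Going by these compounds, the hydroxy is seen here only with the urea of compound 2 and its 4-chloro-3-(trifluoromethyl)phenyl group, so it remains open whether the same change would read alike on the amide of compound 1. The compounds shown also leave open how a longer chain on this oxygen, such as ethoxy or propoxy, or an amine or a fluorine in place of the oxygen, would read in this assay.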